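Replacing the 2,3-dichlorophenyl group on a shared core

The source may report more compounds than this note shows. Statements on the series, on what has been measured and on what is new or still open speak of the compounds shown alone.

In a functional assay (aorta) with Oryctolagus cuniculus as the target (on this read-out lower numbers stand for stronger inhibition and higher numbers for weaker inhibition), compound 1 `CO/C(O)=C1\C(C)=NC(C)=C(C(=O)OCCCN2C(=O)c3ccccc3S2(=O)=O)C1c1cccc(Cl)c1Cl` gives 0.8 nM, compound 2 `CC1=NC(C)=C(C(=O)OCCCN2C(=O)c3ccccc3S2(=O)=O)C(c2cccc(Cl)c2Cl)/C1=C(\O)OC(C)C` gives 2.1 nM and compound 3 `CC1=NC(C)=C(C(=O)OCCCN2C(=O)c3ccccc3S2(=O)=O)C(c2cccc(Cl)c2Cl)/C1=C(\O)OCC1CCCCO1` gives 4 nM. Compound 3 therefore stands level with its nearest neighbour, as a 1.9-fold higher number from compound 2 to compound 3 (0.28 log units; within the scatter) shows, but apart from the other measured compound, as a 5.0-fold higher number from compound 1 to compound 3 (0.70 log units; beyond the scatter) shows.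

Compound 4 `CC1=NC(C)=C(C(=O)OCCCN2C(=O)c3ccccc3S2(=O)=O)C(c2ccccc2C(F)(F)F)/C1=C(\O)OCC1CCCCO1` keeps the (oxan-2-yl)methyl group of compound 3 and differs elsewhere: it carries 2-(trifluoromethyl)phenyl in place of 2,3-dichlorophenyl on a saturated ring carbon.

For the measured compounds named here, none of the measured steps touches that place. All three change only the group on the oxygen, including a 2.6-fold higher number from compound 1 to compound 2 (0.42 log units; beyond the scatter), so they bear on the new change only indirectly. They show how far the numbers in this small set have moved, but they give no direction for the exchange at hand. Going by the values given here, with no example of this change in the data, no step beyond the scatter can be expected in either direction in this assay, although the uncertainty is wide. The expected result is a 1.3-fold higher number from compound 3 to compound 4 (0.10 log units; within the scatter). For compound 4 the estimated value is 5 nM, with an expected range from 1.5 nM to 16 nM.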

Compound 4, half-maximal inhibitory concentration: 1.4 nM
For compound 4 the middle estimate is 3.6-fold (0.55 log units) above the measured one; the whole stated range lies above it.
By their numbers in this assay, from the lowest: compounds 1, 4, 2 and 3 (each within the scatter of the next, the first and the last beyond it).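

For the compounds shown here, the exchange of 2,3-dichlorophenyl for 2-(trifluoromethyl)phenyl on the saturated ring carbon is the first change at this place in the set, and with the (oxan-2-yl)methyl group held constant in this assay, it gives a 2.9-fold lower number from compound 3 to compound 4 (0.46 log units; beyond the scatter). Going by these compounds alone, the earlier steps concerned only the group on the oxygen, so this is the first evidence that the numbers also respond to the aromatic group, here moving towards stronger inhibition. The two groups share a six-membered aromatic ring of carbon only and differ in their substituents, with 10 heavy atoms in the entering group against 8 in the leaving one, but nothing available accounts for the shift in the number.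

This single pair leaves open whether the same exchange would move the numbers similarly with the methyl or isopropyl group of compound 1 or compound 2 on the oxygen. It also leaves open how an unsubstituted phenyl, a nitrophenyl or a pyridine ring would behave at this place, so no trend across aromatic groups can yet be drawn.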